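Series notes: piperidin-1-yl for dimethylamino, compound 4

The compounds below may be only part of what the source reports. "The series", "measured", "known", "first", "only" and "open" are said of these compounds alone.

Measured so far:
Compound 1 `CCN1C(N2CCCCC2)=Nc2ccccc2C1CC(=O)NCc1ccccc1` gives 59.3% in an assay on HEK293 cells for inhibition of Voltage-dependent T-type calcium channel subunit alpha-1G (Homo sapiens), tested at 10 uM; a lower number here means less inhibition, a higher number more inhibition at the concentration tested (going by the name of the read-out).
Compound 2 `CCN1C(N(C)C)=Nc2ccccc2C1CC(=O)NCc1ccc(NS(=O)(=O)c2ccc(C)cc2)cc1` gives 81.3% in this assay.
Compound 3 `CCN1C(N(C)C)=Nc2ccccc2C1CC(=O)NCc1ccc(NS(=O)(=O)c2ccc(F)cc2)cc1` gives 62.7% in this assay.

Compound 2 stands highest of the three numbers; compound 3 is the nearest, and compound 1 the furthest, both beyond the scatter. Among the measured compounds shown here, the only step between compounds that differ in one place is a number 18.6 percentage points lower from compound 2 to compound 3 (beyond the scatter), a change on the aromatic carbon of the sulfonyl-bearing ring that has nothing to do with the change now in question.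

Compound 4 `CCN1C(N2CCCCC2)=Nc2ccccc2C1CC(=O)NCc1ccc(NS(=O)(=O)c2ccc(C)cc2)cc1` differs from compound 2 as follows: piperidin-1-yl in place of dimethylamino on a carbon with a double bond to nitrogen. For the measured compounds named here, no measured step covers this change. Going by the values given here, compound 1 carries the piperidin-1-yl group, but it also lacks the sulfonamide-bearing part of compound 2, so the gap between compound 1 and compound 2 mixes two changes and shows only that the two values differ beyond the scatter. Among the compounds with values here, with no step bearing directly on the exchange of dimethylamino for piperidin-1-yl, the expectation for compound 4 in this assay is a step of a number 5.3 percentage points lower from compound 2 to compound 4 (within the scatter), within the scatter or slightly downward. Compound 4 is estimated at 76%, between 58% and 92%.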

Compound 4, a percentage reported as inhibition, at one concentration (the size of the read-out at that concentration, not a potency): 91.3%
Estimate against measurement, compound 4: 15.3 percentage points below, and the stated range covers the measured number.
By their numbers in this assay, from the lowest: compounds 1 and 3 (each within the scatter of the next); then compounds 2 and 4 (each within the scatter of the next).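

In this assay the exchange of dimethylamino for piperidin-1-yl on the carbon with a double bond to nitrogen gives a number 10 percentage points higher from compound 2 to compound 4 (within the scatter) and so shows that this place, between two ring nitrogen atoms, takes a six-membered non-aromatic ring of 6 heavy atoms in place of a group of 3 heavy atoms with no difference beyond the scatter. With piperidin-1-yl held constant, ((4-methylphenyl)sulfonyl)amino in place of hydrogen on an aromatic carbon gives a number 32 percentage points higher from compound 1 to compound 4 (beyond the scatter) and isolates in one clean step the contribution of that group, which the gap between compound 1 and compound 2 had mixed with the change at the other place. No evidence in hand bears on the origin of either step.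

Going by these compounds, whether a morpholin-4-yl ring or an open diethylamino group would read like piperidin-1-yl and dimethylamino at this carbon remains open, so the level numbers seen here rest on a single pair. Also open, on these data alone, is whether fluoro in place of methyl on the sulfonyl-bearing ring carries the same step when piperidin-1-yl is present.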